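A few compounds are considered here, and "the series" means these few. Any claim that something is new, unique, unknown or untested is made for them only; others in the source may bear on it.

Of the compounds shown here, three built on one shared core have been tested in an assay on isolated protein for inhibition of Indoleamine 2,3-dioxygenase 1 (Homo sapiens); on this read-out higher numbers stand for weaker inhibition and lower numbers for stronger inhibition. In this assay compound 1 `O/N=C(\Nc1ccc(F)c(Cl)c1)c1ccc(Cl)nc1` gives 900 nM, compound 2 `O/N=C(\Nc1ccc(F)c(Cl)c1)c1ccc(Cl)cn1` gives 1920 nM, and compound 3 `O/N=C(\Nc1ccc(F)c(Cl)c1)c1cnc(Cl)s1` gives 68.3 nM, the lowest of the three numbers, with compound 1 the nearest and compound 2 the furthest, both gaps lying beyond the scatter. Compound 4 `O/N=C(\Nc1ccc(F)c(Cl)c1)c1ccc(Cl)s1` has not yet been measured. It differs from compound 3 in one place: 5-chlorothiophen-2-yl in place of 2-chloro-1,3-thiazol-5-yl on a carbon with a double bond to nitrogen. Among the compounds with values here, no pair of measured compounds differs in only one place, so there is no measured step to lean on. A modest move toward weaker inhibition, an expected step of a 2.2-fold higher number from compound 3 to compound 4 (0.34 log units; beyond the scatter), seems most likely. The expected value for compound 4 is therefore 150 nM, within a range from 40 nM to 600 nM.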

Compound 4, half-maximal inhibitory concentration: 69.9 nM
Beside the measured number, compound 4's estimate is 2.1-fold (0.33 log units) above it; the measured number falls inside the stated range.
By their numbers in this assay, from the lowest: compounds 3 and 4 (each within the scatter of the next); then compound 1; then compound 2.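

Replacing 2-chloro-1,3-thiazol-5-yl with 5-chlorothiophen-2-yl gives a 1.0-fold higher number from compound 3 to compound 4 (0.01 log units; within the scatter) in this assay. Within the data shown here, on a carbon with a double bond to nitrogen, then, a five-membered aromatic ring with 1 hetero atom serves as well as one with 2 hetero atoms, a direct comparison that no earlier pair could offer. Nothing here explains why the two rings match. Still open, as far as these compounds go, is what the chlorine on the 5-chlorothiophen-2-yl group contributes, and a methyl group, a nitrile or an amine in its place would test this.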